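The source may report more compounds than this note shows. Statements on the series, on what has been measured and on what is new or still open speak of the compounds shown alone.

Measured so far:
compound 1 `O=c1ccn(COCCO)c(=O)[nH]1` — > 400 ug/mL
compound 2 `Cc1cn(COCCO)c(=O)[nH]c1=O` — > 400 ug/mL
compound 3 `Nc1nc(=O)n(COCCO)cc1[N+](=O)[O-]` — > 400 ug/mL

In a functional assay (Oryctolagus cuniculus) for inhibition (on this read-out lower numbers stand for stronger inhibition and higher numbers for weaker inhibition), compound 1 gives > 400 ug/mL, which is a limit of the assay and not a number. Compound 2 gives > 400 ug/mL, again a limit. Compound 3 gives > 400 ug/mL, also a limit. Compound 2 thus stands at the limit of > 400 ug/mL in this assay, at which 3 of the 3 values shown sit, so no true number is known for it. Among the measured compounds shown here, the only single-point step measured, a step that the two limits leave unreadable from compound 1 to compound 2, cannot be read for size or direction.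

Compound 4 `O=c1[nH]c(=O)n(COCCO)cc1/C=C/Br` differs from compound 2 by 2-bromoethenyl in place of methyl on an aromatic carbon. For the measured compounds named here, no measured step tells how such a change acts in this assay, so the expected step of a number no higher from compound 2 to compound 4 (the limit leaves the size open) is set near zero with a wide range. Compound 4 is therefore estimated at 400 ug/mL, between 50 ug/mL and 1000 ug/mL, and a limit may well be reported again.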

Compound 4, concentration for 50% inhibition: > 400 ug/mL
Compound 4 ended at the assay's limit; the forecaster's own chance of this, stated with the estimate: 70%; the middle value lies on the limit itself.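

Compound 4 gives only a limit in this assay, as do compound 1 and compound 2, so the steps from either one to compound 4 cannot be read: the limit of > 400 ug/mL in this assay, at which 4 of the 4 values shown sit. The compounds shown leave open whether any change on the shared core gives inhibition strong enough to read as a number.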